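The source may report more compounds than this note shows. Statements on the series, on what has been measured and on what is new or still open speak of the compounds shown alone.

In an assay on Sf9 cells for inhibition of histone deacetylase 11 (Homo sapiens), read by fluorescence, tested at 0.5 uM (a lower number here means less inhibition, a higher number more inhibition at the concentration tested (going by the name of the read-out)), compound 1, with structure `O=C(NO)c1cccc(-c2cn([C@H]3C[C@H](CO)N(CCCc4ccccc4)C3)nn2)c1`, gives < 10%, which is a limit of the assay rather than a number. Compound 2, with structure `O=C(NO)c1cccc(-c2cn([C@H]3C[C@@H](CO)N(CCCc4ccccc4)C3)nn2)c1`, gives in this assay < 10%, again a limit of the assay and not a number. For the measured compounds named here, the only measured step, a step that the two limits leave unreadable from compound 1 to compound 2, therefore stays unreadable in size, because the limit of < 10% in this assay, at which 2 of the 2 values shown sit, leaves no room for a readable change between two values that both sit at the floor of the read-out, and because the fact that compounds 1 and 2 differ only in the configuration as drawn makes the pair a change of configuration alone.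

Compound 3, with structure `O=C(NO)c1cccc(-c2cn([C@@H]3C[C@@H](CO)N(CCCc4ccccc4)C3)nn2)c1`, is not yet measured. Its difference from compound 2 is the two compounds have the same atoms and bonds and differ only in configuration as drawn: 1 of 2 stereo elements differ; a stereocentre at a saturated ring carbon is drawn S in compound 2 and R in compound 3. Going by the values given here, the one measured step that bears on it is a change of configuration of the same kind, and that step could not be read, as its two values both sit at the limit. No change beyond the usual scatter is therefore expected in this assay from compound 2 to compound 3, that is, an expected step that the limit leaves unreadable from compound 2 to compound 3. Compound 3 is estimated to give about 5% in this assay, within a range from 0% to 15%, most likely reported again as a limit.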

Compound 3, a percentage reported as inhibition, at one concentration (the size of the read-out at that concentration, not a potency): < 10%
Compound 3: a limit, no number; the forecaster's own chance of this, stated with the estimate: 80%; the middle value is on the limit's open side.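

In this assay compound 3 gives < 10%, which is a limit of the assay and not a number. For the compounds shown here, no step among compound 1, compound 2 and compound 3 can be read, because all three share one limit: the limit of < 10% in this assay, at which 3 of the 3 values shown sit. The compounds shown leave open whether configuration at either stereocentre affects inhibition in this assay at all.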